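A few compounds are considered here, and "the series" means these few. Any claim that something is new, unique, unknown or untested is made for them only; others in the source may bear on it.

Compound 1 `CC(C)=CC[C@@H](OC(=O)c1ccco1)C1=CC(=O)c2c(O)ccc(O)c2C1=O`: 80300 nM
Compound 2 `CCCC(O)CC(=O)O[C@H](CC=C(C)C)C1=CC(=O)c2c(O)ccc(O)c2C1=O`: 59300 nM
Compound 3 `COC(C)CO[C@H](CC=C(C)C)C1=CC(=O)c2c(O)ccc(O)c2C1=O`: 53400 nM

In a functional assay on HeLa cells (Homo sapiens) for cytotoxicity, read by MTT assay (on this read-out lower numbers stand for stronger inhibition and higher numbers for weaker inhibition), compound 3 stands level with the other two compounds, as a 1.1-fold lower number from compound 2 to compound 3 (0.05 log units; within the scatter) and a 1.5-fold lower number from compound 1 to compound 3 (0.18 log units; within the scatter) show. Compound 4 `CC(=O)OCCC(=O)O[C@H](CC=C(C)C)C1=CC(=O)c2c(O)ccc(O)c2C1=O` differs from compound 3 by (2-acetoxyethyl)carbonyl in place of 2-methoxypropyl on an oxygen on a saturated carbon. The closest evidence is the pair of steps just given, which placed 2-methoxypropyl where compound 1 and compound 2 carry a carbonyl group. The exchange of one carbonyl group for another, a 1.4-fold lower number from compound 1 to compound 2 (0.13 log units; within the scatter), bears on it too. None of these steps left the scatter, so no change beyond the scatter is expected. The expected step is a 1.2-fold higher number from compound 3 to compound 4 (0.06 log units; within the scatter). For compound 4 the estimate is 62000 nM, with an expected range from 30000 nM to 125000 nM.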

Compound 4, half-maximal inhibitory concentration: 17300 nM
For compound 4 the middle estimate is 3.6-fold (0.55 log units) above the measured one; the measured number lies below the stated range.
By their numbers in this assay, from the lowest: compound 4; then compounds 3, 2 and 1 (each within the scatter of the next).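

At this place, on an oxygen on a saturated carbon, the earlier groups stayed within the scatter of one another in this assay, whereas (2-acetoxyethyl)carbonyl stands apart (a 3.1-fold lower number from compound 3 to compound 4 (0.49 log units; beyond the scatter)). It also stands apart from the two other carbonyl-linked groups, with 2-hydroxypentyl (a 3.4-fold lower number from compound 2 to compound 4 (0.54 log units; beyond the scatter)) and furan-2-yl (a 4.6-fold lower number from compound 1 to compound 4 (0.67 log units; beyond the scatter)), so a carbonyl here does not alone set the number. No measurement available here accounts for this shift. From the compounds shown here alone, whether a hydroxyl or an amine in place of the acetoxy group would keep the lower number remains open.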